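Swapping bromine for fluorine on a weak IL15 blocker

This account rests on a few compounds, and the source may have more. Where it says the series, first, only, none or still open, it means among the compounds named here.

Measured compounds:
Compound 1 `Cn1c(Cc2nn(C)c(=O)c3ccccc23)nnc1SCCCCCCCCCCC(=O)Nc1ccc(Cl)cc1Cl`: 142000 nM
Compound 2 `Cn1c(Cc2nn(C)c(=O)c3ccccc23)nnc1SCCCCCCCC(=O)Nc1ccc(Br)cc1Br`: 92000 nM

Both compounds were tested in an assay on cells for inhibition of IL15-IL15 receptor (Homo sapiens), read by AlphaScreen, with stated times of 30 min and 1 h; on this read-out lower numbers stand for stronger inhibition and higher numbers for weaker inhibition. Compound 2 gives 92000 nM and compound 1 gives 142000 nM; the gap between these two numbers lies within the usual scatter of such measurements, so neither compound can be called stronger than the other. Both block the interaction only weakly.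

Compound 3 `Cn1c(Cc2nn(C)c(=O)c3ccccc23)nnc1SCCCCCCCC(=O)Nc1ccc(F)cc1F` is not yet measured. It differs from compound 2 in one place: 2,4-difluorophenyl in place of 2,4-dibromophenyl on an amide-type nitrogen. Among the measured compounds shown here, no step between two measured compounds with a change of this kind is known, so the expectation rests on the two measured values alone. Because compound 2 gives 92000 nM and compound 1 gives 142000 nM, both far up the scale, a step of roughly a 1.6-fold higher number from compound 2 to compound 3 (0.21 log units; within the scatter) towards weaker inhibition is expected, though a step no larger than the scatter would not surprise. Compound 3 is therefore estimated at 150000 nM, with a likely range from 50000 nM to 500000 nM.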

Compound 3, half-maximal inhibitory concentration: 110000 nM
Estimate against measurement, compound 3: 1.4-fold (0.13 log units) above; the range from low to high includes it.
By their numbers in this assay, from the lowest: compounds 2, 3 and 1 (each within the scatter of the next).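

Among the compounds shown here, the step from the 2,4-dibromophenyl to the 2,4-difluorophenyl on the amide-type nitrogen is the first one here that alters a single place: in this assay it reads a 1.2-fold higher number from compound 2 to compound 3 (0.08 log units; within the scatter). Compound 2 and compound 3 therefore cannot be told apart, and for this pair inhibition stays weak with either halogen on the ring. No measurement is available that would explain this result.

Still open, from the compounds shown here alone, is whether any other group on that nitrogen would give a clearly different number, such as an unsubstituted phenyl or a phenyl carrying an amine or a carboxylic acid. The effect of chain length also remains unresolved: compound 1 has a longer chain than compound 2 but also carries different halogens, so the two changes cannot be separated.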